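A few compounds are considered here, and "the series" means these few. Any claim that something is new, unique, unknown or untested is made for them only; others in the source may bear on it.

In a functional assay on DU-145 cells (Homo sapiens) for inhibition, read by trypan blue exclusion, with a stated time of 72 h (on this read-out higher numbers stand for weaker inhibition and lower numbers for stronger inhibition), compound 1 `Cn1c(=O)c(S(=O)(=O)c2ccc(F)cc2F)cc2cnc(Nc3ccc4[nH]c(C(=O)O)cc4c3)nc21` gives 10000 nM, while compound 2 `Cn1c(=O)c(S(=O)(=O)c2ccc(F)cc2F)cc2cnc(Nc3ccncn3)nc21` gives 50000 nM, the higher of the two numbers and so the weaker inhibition. Compound 3 `Cn1ccc2cc(Nc3ncc4cc(S(=O)(=O)c5ccc(F)cc5F)c(=O)n(C)c4n3)ccc21` carries 1-methyl-1H-indol-5-yl in place of pyrimidin-4-yl on a nitrogen on an aromatic ring. Going by the values given here, only one measured step bears on this. The step of a 5.0-fold higher number from compound 1 to compound 2 (0.70 log units; beyond the scatter) put pyrimidin-4-yl in place of 2-carboxy-1H-indol-5-yl, so the return to a related group in compound 3 is expected to undo much of it. The expected change is a 5.0-fold lower number from compound 2 to compound 3 (0.70 log units; beyond the scatter), towards stronger inhibition. The estimate for compound 3 is 10000 nM, ranging from 3000 nM to 30000 nM.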

Compound 3, half-maximal inhibitory concentration: 750 nM
Estimate against measurement, compound 3: 13-fold (1.12 log units) above, and the stated range ends above it.
By their numbers in this assay, from the lowest: compound 3; then compound 1; then compound 2.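

In this assay, the group on this nitrogen matters more than the earlier pair showed, with a large gain on moving to 1-methyl-1H-indol-5-yl (a 67-fold lower number from compound 2 to compound 3 (1.82 log units; beyond the scatter)). Compound 3 also beats the carboxy-bearing indole (a 13-fold lower number from compound 1 to compound 3 (1.12 log units; beyond the scatter)), so strong inhibition here does not require the carboxy group. Nothing measured here explains either gain.

As far as these compounds go, that last step changes the carboxy group and the methyl together, so their separate contributions remain unknown. Also open, from the compounds shown here alone, is how an amine or a longer chain in place of that methyl would behave.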